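Removing the sulfonylamino group from compound 1

This account rests on a few compounds, and the source may have more. Where it says the series, first, only, none or still open, it means among the compounds named here.

Measured in a functional assay on KB cells (Homo sapiens) for antiproliferative activity, read by sulforhodamine B assay, with a stated time of 48 h; on this read-out lower numbers stand for stronger inhibition of growth and higher numbers for weaker inhibition of growth:
- Compound 1 `COc1cccc(S(=O)(=O)Nc2ccccc2CCc2ccc(C(=O)Nc3ccccc3N)cc2)c1`: 462 nM
- Compound 2 `COc1ccc(S(=O)(=O)Nc2ccccc2NCc2ccc(C(=O)Nc3ccccc3N)cc2)cc1`: 12 nM
- Compound 3 `COc1ccc(S(=O)(=O)Nc2ccccc2-c2ccc(C(=O)Nc3ccccc3N)cc2)cc1`: 442 nM

Compound 1 and compound 3 sit together at the high end of these numbers, within the scatter of each other. Compound 2 lies below both, beyond the scatter. These three compounds differ in more than one place, so no single-change step can be read from them.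

Compound 4 `Nc1ccccc1NC(=O)c1ccc(CCc2ccccc2)cc1` is the next compound to follow from compound 1. The change is hydrogen in place of ((3-methoxyphenyl)sulfonyl)amino on an aromatic carbon.

The data do not show what losing this group does, since every measured compound carries a methoxyphenyl sulfonylamino group. The nearest reference is compound 1 at 462 nM, and the expectation is weaker inhibition of growth than that, though the basis is thin. The estimated 5.4-fold higher number from compound 1 to compound 4 (0.73 log units; beyond the scatter) is a moderate rise in the number, expected to lie beyond the scatter. Compound 4 is expected at 2500 nM in this assay, with an estimated range of 700 nM to 9000 nM.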

Compound 4, concentration for 50% growth inhibition: > 10000 nM
Compound 4 was reported as a limit; the forecaster's own chance of this, stated with the estimate: 15%; middle value at least 4.0-fold (0.60 log units) from the limit.
By their numbers in this assay, from the lowest: compound 2; then compounds 3 and 1 (each within the scatter of the next). At a limit, above all of these: compound 4.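

In this assay, within the data shown here, hydrogen in place of ((3-methoxyphenyl)sulfonyl)amino on this aromatic carbon, ortho to a large group, gives an at least 21-fold higher number from compound 1 to compound 4 (1.33 log units; beyond the scatter), the first single-change step and a large one. Compounds 1, 2 and 3 all carry a methoxyphenyl sulfonylamino group and could not show this: for this pair, the core of compound 1 without the group loses growth inhibition down to the end of the measured range, so the group at this place matters for the values seen in compound 1. Compound 4 is reported as a limit and not a number: the limit of > 10000 nM in this assay, at which 1 of the 4 values shown sits.

As far as these compounds go, only the whole group leaves in this step, so it stays open which part of it counts, and a smaller group on the same carbon, such as a plain amine or a methanesulfonylamino group, would separate the methoxyphenyl part from the sulfonylamino part. Whether the same loss holds for compound 2 or compound 3 cannot be read, as they differ from compound 4 in more than one place.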